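Replacing a Nitro Group with a Thiophene Ring

The source may hold more compounds than are shown below. What is called first, only, known or untested is meant among the compounds shown, and "the series" means these compounds.

Measured compounds:
Compound 1: `Cc1[nH]c2ccc(Br)cc2c1C1=CCNCC1`, 10 nM
Compound 2: `Cc1[nH]c2ccc([N+](=O)[O-])cc2c1C1=CCNCC1`, 10 nM

Two compounds share one core and differ only in the group on the carbon-only six-membered ring. In an assay on HEK293 cells for displacement of a labelled ligand from 5-hydroxytryptamine receptor 6 (Homo sapiens), read by scintillation counting, with a stated time of 1 h (a lower number here means a stronger inhibitor, a higher number a weaker inhibitor), compound 1 gives 10 nM. Compound 2 gives 10 nM in this assay. Among the measured compounds shown here, the single measured step, no change at the digits printed from compound 1 to compound 2 (within the scatter), shows that exchanging one small substituent for another at this carbon left the result unchanged. Compound 2 therefore stands level with compound 1, within the scatter.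

Compound 3 (`Cc1[nH]c2ccc(-c3ccsc3)cc2c1C1=CCNCC1`) differs from compound 2 by thiophen-3-yl in place of nitro on an aromatic carbon. For the measured compounds named here, only the step from compound 1 to compound 2 bears on this position, and it was flat, which shows the position accepts two different small groups without loss. Nothing measured shows how a five-membered aromatic ring, larger than either, fares there, so the expectation in this assay is a step of modest size at most, leaning slightly towards weaker, with wide uncertainty. Compound 3 is expected to give 20 nM, with a range from 5 nM to 100 nM. The expected step is a 2.0-fold higher number from compound 2 to compound 3 (0.30 log units; within the scatter).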

Compound 3, half-maximal inhibitory concentration: 700 nM
Beside the measured number, compound 3's estimate is 35-fold (1.54 log units) below it; measured number outside the range, above it.
By their numbers in this assay, from the lowest: compounds 1 and 2 (each within the scatter of the next); then compound 3.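

In this assay, thiophen-3-yl in place of nitro gives a 70-fold higher number from compound 2 to compound 3 (1.85 log units; beyond the scatter) and thiophen-3-yl in place of bromo gives a 70-fold higher number from compound 1 to compound 3 (1.85 log units; beyond the scatter) in the same assay, so this aromatic carbon is far from indifferent to what it carries. The earlier flat result, no change at the digits printed from compound 1 to compound 2 (within the scatter) for the exchange of bromo for nitro, therefore held only for those two groups and did not extend to every group at this position. No measurement shown here explains the loss, so the contributions of the five heavy atoms, the five-membered aromatic ring and the sulfur atom of thiophen-3-yl cannot be told apart.

As far as these compounds go, whether the loss belongs to thiophen-3-yl in particular or to any ring on this carbon remains open, and a phenyl ring, a furan-3-yl ring or thiophen-2-yl would help to settle that. From the compounds shown here alone, it is also open whether other small groups, such as an amine, a methoxy group or a carboxylic acid, would stay level with bromo and nitro or fall away as thiophen-3-yl does.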